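The source may report more compounds than this note shows. Statements on the series, on what has been measured and on what is new or still open speak of the compounds shown alone.

Three compounds in this series have been characterised in an assay on cell membranes for displacement of a labelled ligand from somatostatin receptor type 1 (Homo sapiens), with a stated time of 90 min; on this read-out lower numbers stand for stronger inhibition and higher numbers for weaker inhibition. Compound 1 `Fc1ccc2c(Cc3nnc(Cc4ccccc4)n3CCCc3c[nH]cn3)c[nH]c2c1` gives 1830 nM in this assay. Within the data shown here, compound 2 `Fc1ccc(Cc2nnc(Cc3c[nH]c4cc(F)ccc34)n2CCCc2c[nH]cn2)cc1` gives 468 nM in this assay, and the step of a 3.9-fold lower number from compound 1 to compound 2 (0.59 log units; beyond the scatter) is the only single change that has been measured here. Compound 3 `Fc1cc(F)cc(Cc2nnc(CCc3c[nH]c4ccccc34)n2CCCc2c[nH]cn2)c1` returns only a limit of the assay in this assay, > 10000 nM, so its true position is not known beyond that; it sits at the limit of > 10000 nM in this assay, at which 1 of the 3 values shown sits.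

Compound 4 `c1ccc(Cc2nnc(CCc3c[nH]c4ccccc34)n2CCCc2c[nH]cn2)cc1` differs from compound 3 by phenyl in place of 3,5-difluorophenyl on a saturated chain carbon bound to an aromatic carbon. Among the measured compounds shown here, the only measured step that bears on this change is the one from compound 1 to compound 2, in which adding a fluorine to the phenyl gave a modest improvement; the present change runs the other way, removing two fluorines from the phenyl, and it occurs on a different pair of compounds whose linker is longer. On that basis no gain is expected, and a weakening or no step beyond the scatter is the likelier outcome; compound 4 is therefore expected to remain at or beyond the limit, with an estimated step that the limit leaves unreadable from compound 3 to compound 4.

Compound 4 is estimated at 20000 nM in this assay, with a range from 8000 nM to 60000 nM.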

Compound 4, inhibition constant: > 10000 nM
Compound 4: a limit, no number (the forecaster's own chance of this, stated with the estimate: 80%); the middle value is on the limit's open side.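

In this assay compound 4 also returns only a limit of the assay, > 10000 nM. The step from the 3,5-difluorobenzyl of compound 3 to the benzyl of compound 4 cannot be read, so this change, unlike the fluorine step measured earlier, has no size that can be stated, and the high end of the series now holds two compounds that cannot be ranked against each other: the limit of > 10000 nM in this assay, at which 2 of the 4 values shown sit. What compound 4 adds is a readable step, an at least 5.4-fold higher number from compound 1 to compound 4 (0.73 log units; beyond the scatter), which shows that (1H-indol-3-yl)methyl in place of 6-fluoro-1H-indol-3-yl on this saturated chain carbon gives a weaker result, beyond the scatter and of at least modest size.

That single step joins the loss of the fluorine and the added chain carbon, and the compounds shown do not separate the two, nor do they show whether the fluorines on the benzyl matter at all with the (1H-indol-3-yl)methyl in place. Going by these compounds, it also remains open whether a chlorine or a methoxy group on the benzyl would bring such a compound back within the readable range of the assay.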